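This account rests on a few compounds, and the source may have more. Where it says the series, first, only, none or still open, it means among the compounds named here.

Three compounds have been measured in a functional assay on K562 cells (Homo sapiens) for inhibition, with a stated time of 72 h; a higher number here means a weaker inhibitor, a lower number a stronger inhibitor:

- compound 1 `NC1CCC(Nc2nc(NCc3ccc(-c4ccccc4)cc3)c3ncn(C4CCCC4)c3n2)CC1` gives 530 nM
- compound 2 `NC1CCC(Nc2nc(NCc3ccc(-c4cccc(F)c4)nc3)c3ncn(C4CCCC4)c3n2)CC1` gives 61 nM
- compound 3 `CC(C)(O)CNc1nc(NCc2ccc(-c3ccco3)nc2)c2ncn(C3CCCC3)c2n1` gives 1430 nM

Compound 2 is the strongest inhibitor of the three. Both compound 1 and compound 3 lie above it by more than the usual scatter of repeated measurements. For the measured compounds named here, these compounds differ from one another in more than one place, so no measured pair isolates the effect of a single change.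

The next compound to be tested in this assay is compound 4 `NC1CCC(Nc2nc(NCc3ccc(-c4ccccc4O)nc3)c3ncn(C4CCCC4)c3n2)CC1`. It keeps the rest of compound 2 but carries 2-hydroxyphenyl in place of 3-fluorophenyl on an aromatic carbon, next to the ring nitrogen and para to a large group (2-hydroxyphenyl in place of 3-fluorophenyl on an aromatic carbon). Going by the values given here, the data hold no direct precedent for this swap, so any forecast is loose. Compound 2 at 61 nM marks the low end of a range that reaches compound 3 at 1430 nM, and this is the main ground for expecting a rise rather than a fall. A modest weakening, only a little beyond the scatter, is expected, as a 2.5-fold higher number from compound 2 to compound 4 (0.39 log units; beyond the scatter). For compound 4 the estimated value is 150 nM, with an expected range from 40 nM to 550 nM.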

Compound 4, half-maximal inhibitory concentration: 16 nM
The estimate for compound 4 lay 9.4-fold (0.97 log units) above the measured number; the whole stated range lies above it.
By their numbers in this assay, from the lowest: compound 4; then compound 2; then compound 1; then compound 3.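

In this assay, placing 2-hydroxyphenyl in place of 3-fluorophenyl on the aromatic carbon next to the ring nitrogen gives a 3.8-fold lower number from compound 2 to compound 4 (0.58 log units; beyond the scatter), so this position can still yield a stronger inhibitor than compound 2. By the computed counts, both groups hold one six-membered aromatic ring of carbon only, while 2-hydroxyphenyl brings a hydrogen-bond donor and a hydrogen-bond acceptor where 3-fluorophenyl has neither. Nothing available bears on why the number falls.

The compounds shown leave open whether the lower number belongs to the hydroxyl itself or to where it sits on the phenyl ring, a question that a 3-hydroxyphenyl, 2-methoxyphenyl or 2-aminophenyl group on this carbon would help to separate. They also leave open whether the same swap would give a step of similar size alongside the 2-hydroxy-2-methylpropylamino chain of compound 3, which differs from compound 2 in more than one place.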